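Working notes: replacing the aryl group of compound 2

The source may hold more compounds than are shown below. What is called first, only, known or untested is meant among the compounds shown, and "the series" means these compounds.

Values in a functional assay on A549 cells (Homo sapiens) for cytotoxicity, read by MTT assay, with a stated time of 72 h; on this read-out lower numbers stand for stronger inhibition and higher numbers for weaker inhibition:
- compound 1 `O=C(N/N=C/c1cccc(Br)c1)Nc1cc2c(Nc3ccc(F)c(Cl)c3)ncnc2cc1O[C@H]1CCOC1`: 10700 nM
- compound 2 `COc1ccc(/C=N/NC(=O)Nc2cc3c(Nc4ccc(F)c(Cl)c4)ncnc3cc2O[C@H]2CCOC2)c(OC)c1OC`: 25200 nM

Among the compounds with values here, compound 2 holds the higher of the two numbers, and compound 1 is its only measured neighbour. The next compound to consider is compound 3 `O=C(N/N=C/c1ccc(O)cc1O)Nc1cc2c(Nc3ccc(F)c(Cl)c3)ncnc2cc1O[C@H]1CCOC1`, which keeps the shared core and carries 2,4-dihydroxyphenyl in place of 2,3,4-trimethoxyphenyl on a carbon with a double bond to nitrogen.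

Within the data shown here, only one measured step bears on this change, at the same place: a 2.4-fold higher number from compound 1 to compound 2 (0.37 log units; beyond the scatter). Among the measured compounds shown here, it is modest, and no compound with a 2,4-dihydroxyphenyl group has a value yet, so the direction is only weakly supported. Compound 2 at 25200 nM is the upper of the two values, so a modest move towards a lower number is expected rather than a further rise. For the measured compounds named here, the expected change, similar in size to the one measured step, is a 2.1-fold lower number from compound 2 to compound 3 (0.32 log units; beyond the scatter). For compound 3 the estimate in this assay is 12000 nM, with an expected range of 5000 nM to 30000 nM.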

Compound 3, half-maximal inhibitory concentration: 9360 nM
The estimate for compound 3 lay 1.3-fold (0.11 log units) above the measured number; low and high end bracket the measured number.
By their numbers in this assay, from the lowest: compounds 3 and 1 (each within the scatter of the next); then compound 2.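

In this assay, the change from 2,3,4-trimethoxyphenyl to 2,4-dihydroxyphenyl on a carbon with a double bond to nitrogen gives a 2.7-fold lower number from compound 2 to compound 3 (0.43 log units; beyond the scatter), so a second replacement of the trimethoxyphenyl group also ends at a lower number, and this time the entering group carries hydrogen-bond donors where the leaving group has none. The comparison of the two replacements gives a 1.1-fold lower number from compound 1 to compound 3 (0.06 log units; within the scatter), which lies within the scatter, so 3-bromophenyl and 2,4-dihydroxyphenyl cannot be told apart at this position despite sharing only the aromatic ring of carbon, and among the three compounds only compound 2 stands apart. No measurement at hand explains why the trimethoxyphenyl compound separates from the other two.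

The compounds shown leave open whether the higher number of compound 2 goes with the methoxy groups as such or with the substitution of that particular ring, and a 2,4-dimethoxyphenyl group would pair directly with compound 3 on that question. As far as these compounds go, it also remains open whether the flat response extends beyond these groups, for example to an aminophenyl or a carboxyphenyl group at the same place.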